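The source may hold more compounds than are shown below. What is called first, only, known or untested is meant among the compounds shown, and "the series" means these compounds.

Of the compounds shown here, three sharing one core have been tested in an ADME assay on HepG2 cells (Homo sapiens) for cytotoxicity, read by luminescence, CellTiter-Glo and ATP content, with a stated time of 72 h; a lower number here means that less compound is needed, a higher number that more compound is needed for the effect. Compound 1 `c1ccc(CCc2ccc3c(NCCCNCc4ccco4)ccnc3c2)cc1` gives 16000 nM in this assay, and compound 2 `c1ccc(Cc2ccc3c(NCCCNCc4ccco4)ccnc3c2)cc1` gives 16000 nM, so that no change at the digits printed from compound 1 to compound 2 (within the scatter). Compound 3 `COc1ccc(F)cc1CNCCCNc1ccnc2cc(Cc3ccccc3)ccc12` gives 7990 nM. That is the lowest number of the three, yet its gaps to compound 1 and to compound 2 each lie within the scatter, so no real order among the three can be claimed; a 2.0-fold lower number from compound 2 to compound 3 (0.30 log units; within the scatter) likewise stays inside the scatter.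

Compound 4 `COc1ccc(F)cc1CNCCCNc1ccnc2cc(-c3ccc(C(C)(C)C)cc3)ccc12` has not yet been measured. It differs from compound 3 at one place: 4-(tert-butyl)phenyl in place of benzyl on an aromatic carbon. Within the data shown here, the only measured step at this same aromatic carbon is the one where no change at the digits printed from compound 1 to compound 2 (within the scatter), which showed nothing beyond the scatter. Swapping one ring group for another at that place therefore gives no reason to expect a shift. Compared with compound 3, the step expected for compound 4 is a 1.0-fold higher number from compound 3 to compound 4 (0.00 log units; within the scatter). The estimate for compound 4 is 8000 nM, with a range from 3000 nM to 25000 nM.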

Compound 4, half-maximal effective concentration: 620 nM
Estimate against measurement, compound 4: 13-fold (1.11 log units) above; measured number outside the range, below it.
By their numbers in this assay, from the lowest: compound 4; then compounds 3, 1 and 2 (each within the scatter of the next).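

The aromatic carbon that carries benzyl in compound 3 turns out to matter in this assay: 4-(tert-butyl)phenyl there gives a 13-fold lower number from compound 3 to compound 4 (1.11 log units; beyond the scatter), whereas the earlier step at this place, no change at the digits printed from compound 1 to compound 2 (within the scatter), showed nothing. This single step makes two changes at once, since the ring loses its saturated carbon link to the core and also gains a tert-butyl group, so the two cannot be told apart. Nothing in the available data explains why the number falls so far.

An unsubstituted phenyl or a 4-(tert-butyl)benzyl group at this carbon would show which of the two changes carries the step. Going by these compounds, it also remains open whether a smaller group such as methyl, or a charged one such as a carboxylic acid or an amine, in place of tert-butyl would give a similar number.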